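The source may report more compounds than this note shows. Statements on the series, on what has been measured and on what is new or still open speak of the compounds shown alone.

Of the compounds shown here, three sharing one core have so far been measured in an assay for inhibition of MAP kinase-interacting serine/threonine-protein kinase 1 (Homo sapiens), read by luminescence and ADP-Glo, with a stated time of 2 h; a higher number here means a weaker inhibitor, a lower number a stronger inhibitor. Compound 1 `Nc1n[nH]c2cc(-c3ccc(=O)n(Cc4cccc(Cl)c4)c3)ccc12` gives 11 nM; compound 2 `O=c1ccc(-c2ccc3cn[nH]c3c2)cn1Cc1ccccc1` gives 315 nM; compound 3 `CC(=O)Nc1cccc(Cn2cc(-c3ccc4c(N)n[nH]c4c3)ccc2=O)c1` gives 55 nM. Among these three numbers compound 3 stands second highest: compound 1 is its nearest neighbour, and compound 2 lies furthest from it. Compound 4 `Nc1n[nH]c2cc(-c3ccc(=O)n(Cc4ccccc4)c3)ccc12` has not yet been measured. It differs from compound 3 in one place, (hydrogen in place of acetamido on an aromatic carbon), so that the ring bearing the large group is left bare there. For the measured compounds named here, only one measured step bears on this change, namely a 5.0-fold higher number from compound 1 to compound 3 (0.70 log units; beyond the scatter), where the chloro of compound 1 was exchanged for the acetamido of compound 3. Compound 4 carries neither group at that place, and its number is therefore expected to fall between those of compound 1 and compound 3, an estimated step of a 2.2-fold lower number from compound 3 to compound 4 (0.34 log units; beyond the scatter) toward a lower number. For compound 4 the expected value in this assay is 25 nM, with a range from 8 nM to 80 nM.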

Compound 4, half-maximal inhibitory concentration: 79 nM
Compound 4: the middle estimate sits 3.2-fold (0.50 log units) below what was measured; the measured number falls inside the stated range.
By their numbers in this assay, from the lowest: compound 1; then compounds 3 and 4 (each within the scatter of the next); then compound 2.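

In this assay, hydrogen in place of acetamido on this aromatic carbon stays within the scatter (a 1.4-fold higher number from compound 3 to compound 4 (0.16 log units; within the scatter)), so the large acetamido and a bare ring cannot be told apart here, whereas chloro does separate from hydrogen (a 7.2-fold higher number from compound 1 to compound 4 (0.86 log units; beyond the scatter)). This gives a second readable change on the same core, with amino in place of hydrogen on another aromatic carbon and the rest of the molecule unchanged (a 4.0-fold lower number from compound 2 to compound 4 (0.60 log units; beyond the scatter)). No supporting evidence is available to explain any of these steps.

Going by these compounds, it remains open whether a bromo or a methyl at the chloro's place would match the chloro, or whether a carboxylic acid or a longer chain would stay level with hydrogen. The size of the amino step with chloro present is also unknown.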